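Swapping isopropyl for methoxy on a urea in rice

The source may report more compounds than this note shows. Statements on the series, on what has been measured and on what is new or still open speak of the compounds shown alone.

Three ureas built on the same core have been tested in an ADME assay on the whole organism with Oryza sativa as the target, tested at 1 uM; on this read-out higher numbers stand for a weaker effect at the one concentration tested and lower numbers for a stronger effect. Compound 1, `CC(C)c1cccc(NC(=O)N[C@H](C)c2ccccc2)c1`, gives 61%. Compound 2, `CC(C)c1cccc(NC(=O)N[C@@H](C)c2ccccc2)c1`, gives 84%. Compound 3, `C[C@H](NC(=O)Nc1ccccc1C(C)(C)C)c1ccccc1`, gives 99%. Among these, compound 2 stands second highest, with compound 3 above it and compound 1 below it. For the measured compounds named here, the one step measured between neighbours is a number 23 percentage points higher from compound 1 to compound 2 (beyond the scatter), and it rests on (the fact that compounds 1 and 2 differ only in the configuration as drawn).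

Compound 4, `COc1cccc(NC(=O)N[C@@H](C)c2ccccc2)c1`, is the next candidate. It differs from compound 2 by methoxy in place of isopropyl on an aromatic carbon. Going by the values given here, no measured step speaks to this kind of change: the only step on record concerns configuration alone, and compound 3 differs from compound 2 in both the group and its place. There is thus no basis in the numbers for a direction, and the expectation is one of little change beyond the scatter, with wide uncertainty. Compound 4 is expected to give 82% in this assay, within 55% to 100%, which means an estimated step of a number 2 percentage points lower from compound 2 to compound 4 (within the scatter).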

Compound 4, a percentage reported as activity, at one concentration (the size of the read-out at that concentration, not a potency): 99%
For compound 4 the middle estimate is 17 percentage points below the measured one; measured number inside the range.
By their numbers in this assay, from the lowest: compound 1; then compound 2; then compounds 3 and 4 (each within the scatter of the next).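

For the compounds shown here, this is the first change of a group at this aromatic carbon, and it is not a silent one in this assay: methoxy in place of isopropyl gives a number 15 percentage points higher from compound 2 to compound 4 (beyond the scatter). With the configuration held as in compound 2, isopropyl therefore goes with the stronger effect of the pair, so this position does respond to what sits on it. The one explanation on record concerns configuration alone and does not bear on this swap, so nothing here accounts for the step.

Methoxy is shown only in the configuration of compound 2, so whether the same step would appear in the configuration of compound 1 remains open. How an ethyl group, a chlorine atom or an amine at this carbon would compare with isopropyl and methoxy is also unknown.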